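Swapping a Methoxypyridyl Arm for a Furan

A few compounds are considered here, and "the series" means these few. Any claim that something is new, unique, unknown or untested is made for them only; others in the source may bear on it.

Among the compounds with values here, compound 1 `COc1cncc(-c2ccnc3c2c(C(C)C)nn3-c2ccc(C(N)=O)c(N[C@H]3CC[C@H](O)CC3)c2)c1` gives 451 nM in a functional assay on SK-BR-3 cells (Homo sapiens) for inhibition, read by CellTiter-Glo, with a stated time of 72 h (on this read-out higher numbers stand for weaker inhibition and lower numbers for stronger inhibition), the lowest of the two numbers measured so far. Compound 2 `CC(C)c1nn(-c2ccc(C(N)=O)c(N[C@H]3CC[C@H](O)CC3)c2)c2ccnc(-c3cnc4ccccc4c3)c12` gives 1720 nM in this assay, a weaker inhibition that lies beyond the scatter. Compound 3 `CC(C)c1nn(-c2ccc(C(N)=O)c(N[C@H]3CC[C@H](O)CC3)c2)c2nccc(-c3ccoc3)c12` has not yet been measured; it differs from compound 1 by furan-3-yl in place of 5-methoxypyridin-3-yl on an aromatic carbon. Within the data shown here, no measured pair shows this kind of change, so the expected step in this assay is small, leaning toward weaker inhibition and possibly not beyond the scatter. Compound 3 is therefore estimated at 700 nM, within 250 nM to 2500 nM, an expected step of a 1.6-fold higher number from compound 1 to compound 3 (0.19 log units; within the scatter).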

Compound 3, half-maximal inhibitory concentration: > 10000 nM
Compound 3 gave a limit, no number; the forecaster's own chance of this, stated with the estimate: 3%; middle value at least 14-fold (1.15 log units) from the limit.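

In this assay, this aromatic carbon proves far less forgiving than a single swap of aromatic rings might suggest: furan-3-yl in place of 5-methoxypyridin-3-yl gives an at least 22-fold higher number from compound 1 to compound 3 (1.34 log units; beyond the scatter). Compound 3 yields no number, only a limit of the assay: the limit of > 10000 nM in this assay, at which 1 of the 3 values shown sits. In this one pair, then, the five-membered ring does not stand in for the six-membered one. The compounds shown leave open whether the loss goes with the smaller ring or with the missing methoxy group. A plain pyridin-3-yl group at this position could separate the two.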